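Chloro for Methyl: Expected Effect on Growth Inhibition

This account rests on a few compounds, and the source may have more. Where it says the series, first, only, none or still open, it means among the compounds named here.

Compound 1 `NS(=O)(=O)c1ccc(-n2nc(-c3ccc(Cl)cc3)cc2-c2cc(O)ccc2O)cc1`: 35400 nM
Compound 2 `Cc1ccc(-c2cc(C3=CC(=O)C=CC3=O)n(-c3ccc(S(N)(=O)=O)cc3)n2)cc1`: 86800 nM

In a functional assay on cells (Cancer cell lines, Homo sapiens) for cytotoxicity, read by sulforhodamine B assay, with a stated time of 48 h (a higher number here means a weaker inhibitor of growth, a lower number a stronger inhibitor of growth), compound 2 gives 86800 nM, the higher of the two numbers, while compound 1 gives 35400 nM, a gap beyond the scatter. Compound 3 `NS(=O)(=O)c1ccc(-n2nc(-c3ccc(Cl)cc3)cc2C2=CC(=O)C=CC2=O)cc1` differs from compound 2 by chloro in place of methyl on an aromatic carbon. Among the measured compounds shown here, no measured pair shares exactly this change, so its size is unknown here. A modest step toward a lower number is expected because compound 1 with the same chloro group gives 35400 nM, though compound 1 also differs elsewhere. Compound 3 is therefore estimated at 60000 nM, within 25000 nM to 150000 nM, an expected step of a 1.4-fold lower number from compound 2 to compound 3 (0.16 log units; within the scatter).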

Compound 3, concentration for total growth inhibition: 50200 nM
Compound 3: the middle estimate sits 1.2-fold (0.08 log units) above what was measured; measured number inside the range.
By their numbers in this assay, from the lowest: compounds 1, 3 and 2 (each within the scatter of the next, the first and the last beyond it).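

In this assay chloro in place of methyl now has a direct reading at this position: a 1.7-fold lower number from compound 2 to compound 3 (0.24 log units; within the scatter) is a step too small to separate the two groups. Likewise a 1.4-fold higher number from compound 1 to compound 3 (0.15 log units; within the scatter) is too small to separate the non-aromatic ring group from the aromatic one on the shared core. No measured evidence here explains either step. On these data alone, whether an amine, a methoxy group or a carboxylic acid in place of the chloro would give a step beyond the scatter stays open.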